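The source may hold more compounds than are shown below. What is called first, only, known or untested is meant among the compounds shown, and "the series" means these compounds.

The measured values in a functional assay on HeLa cells (Homo sapiens) for cytotoxicity, read by ELISA, with a stated time of 4 days (a lower number here means a stronger inhibitor, a higher number a weaker inhibitor), are as follows:

- compound 1 `Cc1ccsc1-c1cc(-c2ccoc2)cc(-c2ccco2)n1` gives 30500 nM
- compound 2 `Cc1ccsc1-c1cc(-c2ccoc2)cc(-c2ccc(Cl)cc2)n1` gives 17400 nM

Among the measured compounds shown here, these are the only two numbers so far, and compound 2 cannot be told apart from compound 1 on them. The step of a 1.8-fold lower number from compound 1 to compound 2 (0.24 log units; within the scatter) is their whole difference, so neither compound can be ranked above the other.

Compound 3 `Cc1ccsc1-c1cc(-c2ccc(Cl)o2)cc(-c2ccc(Cl)cc2)n1` keeps the core, the 3-methylthiophen-2-yl group and the 4-chlorophenyl group of compound 2. It changes the group opposite the ring nitrogen, with 5-chlorofuran-2-yl in place of furan-3-yl on an aromatic carbon in the structure.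

For the measured compounds named here, no measured step touches that place. Going by the values given here, the one available step swapped furan-2-yl for 4-chlorophenyl elsewhere on the core, and it stayed small. It is weak evidence, but it offers no reason to expect a large move, and the data give no firm direction. In this assay the expected outcome is therefore no shift beyond the scatter, and the estimated step is a 1.3-fold lower number from compound 2 to compound 3 (0.13 log units; within the scatter) in size. For compound 3 the estimated value is 13000 nM with an expected range from 5000 nM to 32000 nM in this measurement.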

Compound 3, half-maximal inhibitory concentration: 29300 nM
For compound 3 the middle estimate is 2.3-fold (0.35 log units) below the measured one; the range from low to high includes it.
By their numbers in this assay, from the lowest: compounds 2, 3 and 1 (each within the scatter of the next).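

In this assay, among the compounds shown here, the step of a 1.7-fold higher number from compound 2 to compound 3 (0.23 log units; within the scatter) is the first reading at the place opposite the ring nitrogen, and on it compound 2 and compound 3 cannot be told apart. The position therefore accepts a ring carrying one more heavy atom, a chlorine, without a difference that rises above the scatter, although this single swap alters two things at once: the furan is attached through a different ring carbon, and the chlorine is added. For the compounds shown here, no measurement here offers an explanation for this result, and the single step cannot show how either alteration acts alone.

Still open, as far as these compounds go, is what each alteration does separately, which a plain furan-2-yl at this place, paired with the 4-chlorophenyl group of compound 2, could help to separate. Also open, from the compounds shown here alone, is whether this place would respond to a group of another kind, such as an amine, a carboxylic acid or a longer alkyl chain, since both groups compared here are five-membered aromatic rings with one oxygen.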